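A few compounds are considered here, and "the series" means these few. Any claim that something is new, unique, unknown or untested is made for them only; others in the source may bear on it.

Measured so far in a functional assay on K562 cells (Homo sapiens) for antiproliferative activity, read by MTT assay, with a stated time of 72 h; a lower number here means a stronger inhibitor, a higher number a weaker inhibitor:
- Compound 1 `COc1cc(-c2ncnn2-c2ccc([N+](=O)[O-])cc2)cc(OC)c1OC`: > 10000 nM
- Compound 2 `COc1cc(-n2ncnc2-c2ccccc2)cc(OC)c1OC`: > 10000 nM

Both entries are limits of the assay, not numbers. Compound 1 therefore has no exact position on the scale, and the only summary available is the limit of > 10000 nM in this assay, at which 2 of the 2 values shown sit.

Compound 3 `COc1ccc(-n2ncnc2-c2cc(OC)c(OC)c(OC)c2)cc1` keeps the core of compound 1 and alters a single group: methoxy in place of nitro on an aromatic carbon. In words, this is methoxy in place of nitro on an aromatic carbon, para to a large group.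

Among the compounds with values here, no measured pair shows what this swap does, so the expectation is uncertain. The reference point is compound 1, with its limit of > 10000 nM. In this assay, a moderate to large gain in strength is expected, although compound 3 could also remain at the limit. The estimated step is an at least 5.0-fold lower number from compound 1 to compound 3 (0.69 log units; beyond the scatter). For compound 3, the estimate is 2000 nM, with an expected range of 100 nM to 15000 nM.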

Compound 3, half-maximal inhibitory concentration: 3600 nM
For compound 3 the middle estimate is 1.8-fold (0.26 log units) below the measured one; the measured number falls inside the stated range.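

In this assay, methoxy in place of nitro on an aromatic carbon, para to a large group, is the one change shown that brings a compound from a limit of the assay to a readable number, with an at least 2.7-fold lower number from compound 1 to compound 3 (0.44 log units; beyond the scatter). With the rest of the core of compound 1 kept, this pair shows that the group at this place can decide whether the compound registers in this assay at the concentrations tested. The step is only a minimum and not a measured size, because compound 1 carries a limit and not a number, as does another value in this small set: the limit of > 10000 nM in this assay, at which 2 of the 3 values shown sit.

This single pair cannot separate what is gained by adding methoxy from what is gained by removing nitro, and the compounds shown include no plain hydrogen at this place to serve as a reference. As far as these compounds go, it also remains open whether an amine, a hydroxyl or a longer chain such as ethoxy on the same carbon would extend the gain or lose it.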